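A few compounds are considered here, and "the series" means these few. Any claim that something is new, unique, unknown or untested is made for them only; others in the source may bear on it.

Compound 1 `N#CC1=C(N)Oc2c(c3nc4ccccc4nc3c3ccccc23)C12C(=O)N(Cc1cnnn1-c1ccc(Cl)cc1)c1ccccc12` and compound 2 `CCOc1ccc(-n2nncc2CN2C(=O)C3(C(C#N)=C(N)Oc4c3c3nc5ccccc5nc3c3ccccc43)c3ccccc32)cc1` share one core and differ only in the group carried on an aromatic carbon. In an ADME assay on HUVEC cells (Homo sapiens) for antiproliferative activity, read by MTT assay, with a stated time of 48 h (a higher number here means a weaker inhibitor, a lower number a stronger inhibitor), compound 1 reaches only a limit of the assay, > 50000 nM. In this assay compound 2 likewise gives only a limit, > 50000 nM. The step that the two limits leave unreadable from compound 1 to compound 2 is therefore of unreadable size, because the limit of > 50000 nM in this assay, at which 2 of the 2 values shown sit, holds both of the values that are known. Compound 2 thus stands at the limit of this assay and nowhere on a measured scale, with no number of its own to compare against.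

Compound 3 `Cc1ccc(C)c(-n2nncc2CN2C(=O)C3(C(C#N)=C(N)Oc4c3c3nc5ccccc5nc3c3ccccc43)c3ccccc32)c1` differs from compound 2 by 2,5-dimethylphenyl in place of 4-ethoxyphenyl on an aromatic nitrogen. Among the measured compounds shown here, the only measured step, a step that the two limits leave unreadable from compound 1 to compound 2, concerns the same part of the structure, but its size is hidden by the limit, so it sets no direction and no magnitude for the present change. With nothing pointing to a gain in potency, compound 3 is expected to remain at the limit, with an estimate of 50000 nM and a range from 20000 nM to 200000 nM. The expected step is a number no higher from compound 2 to compound 3 (the limit leaves the size open), meaning none beyond the scatter.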

Compound 3, half-maximal inhibitory concentration: > 50000 nM
Compound 3 gave a limit, no number (the forecaster's own chance of this, stated with the estimate: 85%); the middle value sits exactly at the limit.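

In this assay compound 3 gives > 50000 nM as a limit of the assay. No new step can be read from compound 1 or compound 2 to compound 3, because all three compounds share one limit: the limit of > 50000 nM in this assay, at which 3 of the 3 values shown sit.

The compounds shown leave open whether in this assay any group on the aromatic nitrogen of the shared core gives a measured number.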